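Extending the Side Chain of Compound 2 to Butyl

This account rests on a few compounds, and the source may have more. Where it says the series, first, only, none or still open, it means among the compounds named here.

Compound 2 `Cc1cc2ccccc2nc1-c1cn(-c2ccc(F)cc2)nn1` was tested in a functional assay on COLO 205 cells (Homo sapiens) for cytotoxicity, read by MTT assay, with a stated time of 24 h; a lower number here means a stronger inhibitor, a higher number a weaker inhibitor. In this assay compound 2 gives > 100 ug/mL, which is a limit of the assay rather than a number. Two related compounds were measured alongside it. Compound 1 `CCCCCCCCCCn1cc(-c2nc3ccccc3cc2CCC)nn1` in this assay gives > 100 ug/mL, again a limit and not a number. Going by the values given here, compound 3 `Cc1cc2ccccc2nc1-c1cn(CCC(F)(F)C(F)(F)C(F)(F)C(F)(F)C(F)(F)C(F)(F)C(F)(F)C(F)(F)F)nn1` in this assay gives 75.8 ug/mL, the one numerical value among the three. Compound 2 therefore stands at the limit of > 100 ug/mL in this assay, at which 2 of the 3 values shown sit, with compound 1 beside it, while compound 3 alone falls just inside the measurable range.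

Compound 4 `CCCCc1cc2ccccc2nc1-c1cn(-c2ccc(F)cc2)nn1` has not yet been measured in this assay. It differs from compound 2 by propyl in place of hydrogen on a saturated chain carbon bound to an aromatic carbon. No measured step of this kind exists among the compounds shown. Given that compound 1, which also carries a propyl on its core, gives > 100 ug/mL in this assay, the step of a number no higher from compound 2 to compound 4 (the limit leaves the size open) is expected to be small, most likely none beyond the scatter. Compound 4 is thus expected to give roughly 100 ug/mL, within a range from 55 ug/mL to 200 ug/mL, in this assay, with a considerable chance that only a limit is reported.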

Compound 4, half-maximal inhibitory concentration: > 100 ug/mL
Compound 4: a limit, no number; the forecaster's own chance of this, stated with the estimate: 65%; the middle value sits exactly at the limit.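

Compound 2 and compound 4 are both reported in this assay only as limits of the assay, not as numbers, and no step can be read between them. The compounds shown leave open whether butyl in place of methyl changes the result in this assay at all.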